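Swapping an aryl for a piperazine amide on the shared core

This account rests on a few compounds, and the source may have more. Where it says the series, first, only, none or still open, it means among the compounds named here.

Three compounds share a core in which a sulfonamide links a chlorinated methoxyphenyl ring to a pyridine bearing one variable group. Compound 1 `COc1ccc(Cl)cc1S(=O)(=O)Nc1cncc(-c2cccnc2)c1` carries pyridin-3-yl there; in an assay on isolated protein for inhibition of alkaline phosphatase, tissue-nonspecific isozyme (Homo sapiens) (a lower number here means a stronger inhibitor, a higher number a weaker inhibitor), compound 1 gives 73 nM. Compound 2 `CNC(=O)c1cncc(NS(=O)(=O)c2cc(Cl)ccc2OC)c1` carries methylcarbamoyl and gives 109 nM in this assay. Compound 3 `COc1ccc(Cl)cc1S(=O)(=O)Nc1cncc(-c2ccccc2C)c1` carries 2-methylphenyl and gives 178 nM, the highest of the three numbers; the step of a 2.4-fold higher number from compound 1 to compound 3 (0.39 log units; beyond the scatter) lies beyond the scatter, while a 1.6-fold higher number from compound 2 to compound 3 (0.21 log units; within the scatter) does not.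

Compound 4 `COc1ccc(Cl)cc1S(=O)(=O)Nc1cncc(C(=O)N2CCN(C)CC2)c1` is the next compound. The change from compound 3 is (4-methylpiperazin-1-yl)carbonyl in place of 2-methylphenyl on an aromatic carbon. The step that bears most on this is a 1.6-fold higher number from compound 2 to compound 3 (0.21 log units; within the scatter), since compound 2 also carries a carbonyl-linked group at this position. Running that step in reverse suggests a modest decrease at most, likely within the scatter, and so the expected step is a 1.5-fold lower number from compound 3 to compound 4 (0.17 log units; within the scatter). Compound 4 is therefore estimated to give 120 nM in this assay, with a range from 50 nM to 300 nM.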

Compound 4, half-maximal inhibitory concentration: 671 nM
The estimate for compound 4 lay 5.6-fold (0.75 log units) below the measured number; the whole stated range lies below it.
By their numbers in this assay, from the lowest: compounds 1, 2 and 3 (each within the scatter of the next, the first and the last beyond it); then compound 4.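

In this assay, for the compounds shown here, the first three groups at this position stay fairly close, their widest step being a 2.4-fold higher number from compound 1 to compound 3 (0.39 log units; beyond the scatter), but (4-methylpiperazin-1-yl)carbonyl moves the number clearly past all of them, with a 3.8-fold higher number from compound 3 to compound 4 (0.58 log units; beyond the scatter) and a 9.2-fold higher number from compound 1 to compound 4 (0.96 log units; beyond the scatter). The most telling comparison keeps the carbonyl on the ring and changes only what is attached to it, giving a 6.2-fold higher number from compound 2 to compound 4 (0.79 log units; beyond the scatter), so a carbonyl at this position does not settle the number by itself, and the group on the carbonyl matters too. Nothing measured here explains this rise.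

The compounds shown leave open whether the higher number goes with the ring on the carbonyl or with the methyl-bearing nitrogen in that ring. A morpholine amide or a dimethylamide at this position would help separate those two possibilities.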